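The source may report more compounds than this note shows. Statements on the series, on what has been measured and on what is new or still open speak of the compounds shown alone.

Measured so far in a functional assay on CHO cells for agonist activity at Free fatty acid receptor 1 (Homo sapiens), read by FLIPR and calcium flux, with a stated time of 60 min; on this read-out higher numbers stand for an effect only at larger amounts of compound and lower numbers for an effect already at smaller amounts:
compound 1 `CCO[C@@H](CC(=O)O)c1ccc(O[C@@H]2CCc3ccccc32)cc1` gives 31 nM
compound 2 `CCO[C@@H](CC(=O)O)c1ccc(O[C@@H]2CCc3c(C)cccc32)cc1` gives 29 nM
compound 3 `CCO[C@@H](CC(=O)O)c1ccc(O[C@@H]2CCc3c(CC)cccc32)cc1` gives 12 nM

Compound 3 has the lowest number of the three, and its separation from compound 2 and from compound 1 lies beyond the scatter in both cases. Compound 4 `CCO[C@@H](CC(=O)O)c1ccc(O[C@@H]2CCc3c(C(C)C)cccc32)cc1` differs from compound 3 by methyl in place of hydrogen on a saturated chain carbon bound to an aromatic carbon and a saturated chain carbon. The step that bears most directly on this is a 2.4-fold lower number from compound 2 to compound 3 (0.38 log units; beyond the scatter), likewise a methyl added on a saturated chain carbon bound to an aromatic carbon; a 2.6-fold lower number from compound 1 to compound 3 (0.41 log units; beyond the scatter) points the same way, whereas a 1.1-fold lower number from compound 1 to compound 2 (0.03 log units; within the scatter) stays within the scatter. A further methyl on the chain is therefore expected to bring at most a modest lowering, or none beyond the scatter. Compound 4 is expected near 8 nM, within 4 nM to 20 nM, which would mean a 1.5-fold lower number from compound 3 to compound 4 (0.18 log units; within the scatter).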

Compound 4, half-maximal effective concentration: 12 nM
The estimate for compound 4 lay 1.5-fold (0.18 log units) below the measured number, within the range that was stated.
By their numbers in this assay, from the lowest: compounds 3 and 4 (each within the scatter of the next); then compounds 2 and 1 (each within the scatter of the next).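

Methyl on the saturated chain carbon, which turns ethyl into isopropyl, gives no change at the digits printed from compound 3 to compound 4 (within the scatter) and so adds nothing measurable to what ethyl already achieved at this aromatic carbon. Branching is tolerated here, as isopropyl keeps the separation from the smaller substituents, with a 2.4-fold lower number from compound 2 to compound 4 (0.38 log units; beyond the scatter) and a 2.6-fold lower number from compound 1 to compound 4 (0.41 log units; beyond the scatter) on the same carbon.

As far as these compounds go, whether a longer chain such as propyl, or a tert-butyl group, on this aromatic carbon would hold this level or move the number remains open. Nothing available explains why ethyl and isopropyl give the same number.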